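Fluorine on the azo-linked ring and tolerated concentration

A few compounds are considered here, and "the series" means these few. Any claim that something is new, unique, unknown or untested is made for them only; others in the source may bear on it.

Two compounds share a core built around a saturated bicyclic amine: compound 1 `Fc1ccc(F)c(/N=N/c2ccc(NC[C@@H]3CCCN4CCCC[C@H]34)c3c2CCCC3)c1` and compound 2 `c1ccc(/N=N/c2ccc(NC[C@@H]3CCCN4CCCC[C@H]34)c3c2CCCC3)cc1`. In an ADME assay on MDBK cells (Bos taurus) for cytotoxicity, read by MTT assay, with a stated time of 96 h (a lower number here means that less compound is tolerated, a higher number that more compound is tolerated), compound 1 gives 64000 nM. In this assay compound 2 gives only a limit, > 100000 nM, with the limit of > 100000 nM in this assay, at which 1 of the 3 values shown sits. The change between them is 2,5-difluorophenyl in place of phenyl on a double-bonded nitrogen, and the step it made is an at least 1.5-fold lower number from compound 2 to compound 1 (0.19 log units; that floor lies within the scatter).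

Compound 3 `CN(C)CCCN(/N=N/c1ccccc1)c1cccc(C(F)(F)F)c1` carries a different core; the difference between the two cores is not broken down here. In this assay compound 3 gives 38000 nM, the lowest of the two numbers, with compound 1 being the nearest, though within the scatter.

Compound 4 `CN(C)CCCN(/N=N/c1cc(F)ccc1F)c1cccc(C(F)(F)F)c1` has not yet been measured. It differs from compound 3 by 2,5-difluorophenyl in place of phenyl on a double-bonded nitrogen, the same change as from compound 2 to compound 1. Since that earlier step gave an at least 1.5-fold lower number from compound 2 to compound 1 (0.19 log units; that floor lies within the scatter), the step from compound 3 to compound 4 is expected to be a 1.7-fold lower number from compound 3 to compound 4 (0.24 log units; within the scatter). Compound 4 is therefore estimated at 22000 nM, between 8000 nM and 60000 nM.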

Compound 4, half-maximal cytotoxic concentration: > 100000 nM
Compound 4: a limit, no number (the forecaster's own chance of this, stated with the estimate: 5%); at least 4.5-fold (0.65 log units) between middle value and limit.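

In this assay, 2,5-difluorophenyl in place of phenyl on a double-bonded nitrogen gave an at least 2.6-fold higher number from compound 3 to compound 4 (0.42 log units; beyond the scatter). The step seen on one core therefore did not carry over to the other in size or direction, and the two steps stand apart: the same change on two cores in this assay, an at least 1.5-fold lower number (0.19 log units; that floor lies within the scatter) from compound 2 to compound 1 and an at least 2.6-fold higher number (0.42 log units; beyond the scatter) from compound 3 to compound 4, at least 4.1-fold (0.61 log units) apart, beyond the scatter of two such steps

This does not give the true size of either step or a rule for any further core, since only two cores are compared and each step has a value at the assay's limit, so only a floor is known: the limit of > 100000 nM in this assay, at which 2 of the 4 values shown sit.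

The compounds shown leave open whether a monofluorophenyl, a chlorophenyl or a methoxyphenyl on a double-bonded nitrogen would follow the step on the core of compound 1 or the step on the core of compound 3. They also leave open how a longer chain on the core of compound 3 would read in this assay.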